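From 4-nitrophenyl to 2-chloro-4-fluorophenyl in compound 4

This account rests on a few compounds, and the source may have more. Where it says the series, first, only, none or still open, it means among the compounds named here.

- Compound 1 `O=C(N/N=C/c1ccc(F)cc1Cl)Nc1cc2c(Nc3ccc(F)c(Cl)c3)ncnc2cc1O[C@H]1CCOC1`: 27200 nM
- Compound 2 `COc1cc2ncnc(Nc3ccc(F)c(Cl)c3)c2cc1NC(=O)N/N=C/c1cccc(Br)c1`: 28100 nM
- Compound 3 `COc1cc2ncnc(Nc3ccc(F)c(Cl)c3)c2cc1NC(=O)N/N=C/c1ccc([N+](=O)[O-])cc1`: 35100 nM

These numbers all come from a functional assay on A549 cells (Homo sapiens) for cytotoxicity, read by MTT assay, with a stated time of 72 h; a higher number here means a weaker inhibitor, a lower number a stronger inhibitor. There, compound 3 gives 35100 nM, and this cannot be told apart from the other two, since all three lie within the scatter of one another.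

Compound 4 `COc1cc2ncnc(Nc3ccc(F)c(Cl)c3)c2cc1NC(=O)N/N=C/c1ccc(F)cc1Cl` keeps all of compound 3 except one group: 2-chloro-4-fluorophenyl in place of 4-nitrophenyl on a carbon with a double bond to nitrogen.

For the measured compounds named here, one measured step bears directly on this place: a 1.2-fold higher number from compound 2 to compound 3 (0.10 log units; within the scatter). That exchange of 3-bromophenyl for 4-nitrophenyl stayed within the scatter. Compound 1 already carries the entering 2-chloro-4-fluorophenyl group, though on a core that differs from that of compound 3. With that group, compound 1 gives 27200 nM. No step beyond the scatter is therefore expected in this assay, and the estimated step is a 1.2-fold lower number from compound 3 to compound 4 (0.08 log units; within the scatter). For compound 4 the expected value is 29000 nM, with an estimated range from 15000 nM to 55000 nM.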

Compound 4, half-maximal inhibitory concentration: 28200 nM
Compound 4: the middle estimate sits 1.0-fold (0.01 log units) above what was measured; low and high end bracket the measured number.
By their numbers in this assay, from the lowest: compounds 1, 2, 4 and 3 (each within the scatter of the next).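

In this assay the shared core now carries three different groups on the carbon with a double bond to nitrogen, and 2-chloro-4-fluorophenyl in place of 4-nitrophenyl stays within the scatter (a 1.2-fold lower number from compound 3 to compound 4 (0.10 log units; within the scatter)). The same group in place of 3-bromophenyl also stays within the scatter (a 1.0-fold higher number from compound 2 to compound 4 (0.00 log units; within the scatter)), so these three groups cannot be told apart at this position. For the compounds shown here, compound 4 also gives the first direct comparison at a second place, methyl in place of oxolan-3-yl on an oxygen on an aromatic ring, and this step too stays within the scatter (a 1.0-fold higher number from compound 1 to compound 4 (0.02 log units; within the scatter)).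

No supporting measurement is available to explain these results. On these data alone, whether an amine or a carboxylic acid on the phenyl ring, or a small alkyl chain in place of that ring, would give a step beyond the scatter remains open.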